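Isobutyl to sec-butyl on the amine nitrogen: the remaining analogue

A few compounds are considered here, and "the series" means these few. Any claim that something is new, unique, unknown or untested is made for them only; others in the source may bear on it.

Measured so far in a functional assay on Caco-2 cells (Homo sapiens), read by fluorescence, tested at 1 uM; on this read-out higher numbers stand for a weaker effect at the one concentration tested and lower numbers for a stronger effect:
compound 1 `CCC(C)NC(=C\C(=O)/C=C/c1ccc(O)c(OC)c1)/C=C/c1ccc(O)c(OC)c1`, giving 91%
compound 2 `COc1cc(/C=C/C(=O)/C=C(/C=C/c2ccc(OC(C)=O)c(OC)c2)NCC(C)C)ccc1OC(C)=O`, giving 96%
compound 3 `COc1cc(/C=C/C(=O)/C=C(/C=C/c2ccc(O)c(OC)c2)NCC(C)C)ccc1O`, giving 91%

All three numbers sit close together. Compound 2 shows the highest number of the three, but compound 1 and compound 3 each lie within the scatter of it, so no order among the three is drawn, and none of them is called the strongest or the weakest on this read-out.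

Compound 1 and compound 3 differ in one place only: sec-butyl in place of isobutyl on an amine nitrogen. The step this change made in this assay is no change at the digits printed from compound 3 to compound 1 (within the scatter). Compound 2 and compound 3 carry the same isobutyl chain on the amine nitrogen but differ elsewhere; the difference between the two cores is not broken down here, and only their two values are set side by side.

Compound 4 `CCC(C)NC(=C\C(=O)/C=C/c1ccc(OC(C)=O)c(OC)c1)/C=C/c1ccc(OC(C)=O)c(OC)c1` has not yet been measured in this assay. It stands to compound 2 as compound 1 stands to compound 3: sec-butyl in place of isobutyl on an amine nitrogen. The place of the change is the same in both pairs, the amine nitrogen whose other neighbour is a double-bonded chain carbon, so this is the same change made a second time.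

The step of a number 1 percentage points lower from compound 2 to compound 4 (within the scatter) is expected to stay within the scatter, because the same change gave no change at the digits printed from compound 3 to compound 1 (within the scatter) on the other core. Compound 4 is therefore expected to give 95% in this assay, with the estimate running from 86% to 100%.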

Compound 4, a percentage reported as activity, at one concentration (the size of the read-out at that concentration, not a potency): 95%
Compound 4: the middle estimate sits on the measured number at the digits printed, within the range that was stated.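

In this assay, sec-butyl in place of isobutyl on the amine nitrogen gives a number 1 percentage points lower from compound 2 to compound 4 (within the scatter), and set beside the earlier step on the other core, the result reads: the same change on two cores in this assay, no change at the digits printed (within the scatter) from compound 3 to compound 1 and a number 1 percentage points lower (within the scatter) from compound 2 to compound 4, 1 percentage points apart, within the scatter of two such steps

Within these two pairs, then, the change carries from one core to the other without any step beyond the scatter, and the two cores give no sign of treating the change differently. This is agreement between two steps that cannot be told from no change, not a shared effect of measurable size, and it rests on two cores and a single concentration, so it gives no potency and does not show that the change would stay silent on a further core or at another concentration.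

Both chains compared here are butyl groups, so the compounds shown leave open whether anything placed on this amine nitrogen can move the read-out beyond the scatter on either core. A longer chain, a benzyl group or a chain carrying a carboxylic acid in place of isobutyl would test that question, ideally as matched pairs on both cores.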